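Sulfur substituent swap on the shared core: allyl to nitropyridinyl

The source may report more compounds than this note shows. Statements on the series, on what has been measured and on what is new or still open speak of the compounds shown alone.

Compound 3 `C=CCSc1nc(-c2ccc(C)cc2)nc2ccc(Cl)cc12` gives the highest of the three numbers in a functional assay on HepG2 cells (Homo sapiens) for antiproliferative activity, read by MTT assay, with a stated time of 48 h (on this read-out lower numbers stand for stronger inhibition and higher numbers for weaker inhibition), at 23.9 ug/mL. Compound 1 `Cc1ccc(-c2nc(SCc3ccccc3)c3cc(Cl)ccc3n2)cc1` gives 18.4 ug/mL, and compound 2 `Cc1ccc(-c2nc(SCC#N)c3cc(Cl)ccc3n2)cc1` gives 4.37 ug/mL. Compound 4 `Cc1ccc(-c2nc(Sc3ncccc3[N+](=O)[O-])c3cc(Cl)ccc3n2)cc1` carries 3-nitropyridin-2-yl in place of allyl on a sulfur. All three measured steps alter the group on the sulfur side of the shared core: a 4.2-fold lower number from compound 1 to compound 2 (0.62 log units; beyond the scatter), a 1.3-fold higher number from compound 1 to compound 3 (0.11 log units; within the scatter), a 5.5-fold higher number from compound 2 to compound 3 (0.74 log units; beyond the scatter). Going by these compounds, none of them puts a ring directly on the sulfur in place of a saturated chain, so the direction for compound 4 remains open, and the measured steps point to no more than a modest shift either way. Compound 4 is therefore expected to give about 12 ug/mL in this assay, between 3.5 ug/mL and 40 ug/mL. That estimate corresponds to a 2.0-fold lower number from compound 3 to compound 4 (0.30 log units; within the scatter), an expected step of modest size at most.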

Compound 4, half-maximal inhibitory concentration: 5.59 ug/mL
Compound 4: middle estimate off by 2.1-fold (0.33 log units), on the high side, and the stated range covers the measured number.
By their numbers in this assay, from the lowest: compounds 2 and 4 (each within the scatter of the next); then compounds 1 and 3 (each within the scatter of the next).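

Placing 3-nitropyridin-2-yl on the sulfur gives a 4.3-fold lower number from compound 3 to compound 4 (0.63 log units; beyond the scatter) in this assay and a 3.3-fold lower number from compound 1 to compound 4 (0.52 log units; beyond the scatter) so an aromatic ring bound directly to the sulfur can reach the low end of the numbers in this set. Against cyanomethyl, the same group gives a 1.3-fold higher number from compound 2 to compound 4 (0.11 log units; within the scatter) so these two quite different groups cannot be told apart here. Nothing available accounts for this result.

Open, going by these compounds, is whether the nitro group or the pyridine ring drives the step, a question that pyridin-2-yl or phenyl on the sulfur would address. On these data alone, how an amine or a carboxylic acid on the sulfur chain would read also remains open.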